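The compounds below may be only part of what the source reports. "The series", "measured", "known", "first", "only" and "open" are said of these compounds alone.

Compound 1 `COc1ncc(-c2cc3c(N4C[C@@H](C)O[C@@H](C)C4)ncnc3s2)cc1NS(=O)(=O)c1ccc(F)cc1F` is the stronger of the two measured compounds: in a functional assay on HGC-27 cells (Homo sapiens) for antiproliferative activity, read by MTT assay, with stated times of 72 h and 4 h (on this read-out higher numbers stand for weaker inhibition and lower numbers for stronger inhibition), compound 1 gives 560 nM, the lowest of the two numbers recorded. Within the data shown here, its nearest neighbour is compound 2 `COc1ncc(-c2cc3c(N4CCCCC4)ncnc3s2)cc1NS(=O)(=O)c1ccc(F)cc1F`, which in this assay gives 1200 nM; the only measured step, piperidin-1-yl in place of 2,6-dimethylmorpholin-4-yl on an aromatic carbon, is a 2.1-fold higher number from compound 1 to compound 2 (0.33 log units; beyond the scatter). Compound 3 `COc1ncc(-c2cc3c(N4CC5COCC5C4)ncnc3s2)cc1NS(=O)(=O)c1ccc(F)cc1F` is not yet measured. It differs from compound 1 by a group of 8 heavy atoms (6 carbon, 1 nitrogen, 1 oxygen; 2 five-membered non-aromatic rings with 1 hetero atom each) in place of a group of 8 heavy atoms (6 carbon, 1 nitrogen, 1 oxygen; one six-membered non-aromatic ring with 2 hetero atoms), on an aromatic carbon. Among the measured compounds shown here, the one measured step bears on this change only loosely, since both it and the present change replace the same 2,6-dimethylmorpholin-4-yl at the same position. That step was modest, so a step of similar or smaller size is expected here, most likely a higher number, though none beyond the scatter would not surprise. Compound 3 is therefore expected to give 750 nM in this assay, with a range of 300 nM to 1900 nM, a step of a 1.3-fold higher number from compound 1 to compound 3 (0.13 log units; within the scatter).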

Compound 3, half-maximal inhibitory concentration: 300 nM
For compound 3 the middle estimate is 2.5-fold (0.40 log units) above the measured one, and the stated range covers the measured number.
By their numbers in this assay, from the lowest: compounds 3 and 1 (each within the scatter of the next); then compound 2.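

In this assay, the group with 2 five-membered non-aromatic rings with 1 hetero atom each replaces 2,6-dimethylmorpholin-4-yl on this aromatic carbon with a 1.9-fold lower number from compound 1 to compound 3 (0.27 log units; within the scatter), so the two ring types cannot be told apart on this read-out. Set against piperidin-1-yl, the same group gives a 4.0-fold lower number from compound 2 to compound 3 (0.60 log units; beyond the scatter), and so both oxygen-bearing groups, in compound 1 and compound 3, give lower numbers than the oxygen-free group of compound 2, with no compound here going against this. No supporting measurement is available to explain these differences.

The compounds shown leave open whether plain morpholin-4-yl, without its two methyl groups, or piperazin-1-yl, with a ring nitrogen in place of the oxygen, would match compound 1 or compound 2. They also leave open whether the same ordering would hold with a sulfonamide aryl group other than the shared difluorophenyl.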